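Moving the tetrazole on the thiophene ring

This account rests on a few compounds, and the source may have more. Where it says the series, first, only, none or still open, it means among the compounds named here.

Among the measured compounds shown here, in a functional assay (Pituitary gland cell) with Rattus norvegicus as the target (a lower number here means that less compound is needed, a higher number that more compound is needed for the effect), compound 1 `Cc1noc(-c2ccccc2-c2ccc(CN3C(=O)[C@H](NC(=O)CC(C)(C)N)CCc4ccccc43)cc2)n1` gives 1050 nM, the highest of the three numbers known here. Compound 2 `CC(C)(N)CC(=O)N[C@@H]1CCc2ccccc2N(Cc2ccc(-n3cccc3-c3nn[nH]n3)cc2)C1=O` gives 275 nM in this assay, and compound 3 `CC(C)(N)CC(=O)N[C@@H]1CCc2ccccc2N(Cc2ccc(-c3sccc3-c3nn[nH]n3)cc2)C1=O` gives 140 nM. Both differ from compound 1 only where a five-membered aromatic ring carrying a tetrazole takes the place of the 2-(3-methyl-1,2,4-oxadiazol-5-yl)phenyl group: the result was a 3.8-fold lower number from compound 1 to compound 2 (0.58 log units; beyond the scatter) and a 7.5-fold lower number from compound 1 to compound 3 (0.88 log units; beyond the scatter), while the remaining step was only a 2.0-fold lower number from compound 2 to compound 3 (0.29 log units; within the scatter). Compound 4 `CC(C)(N)CC(=O)N[C@@H]1CCc2ccccc2N(Cc2ccc(-c3cscc3-c3nn[nH]n3)cc2)C1=O` is not yet measured. It differs from compound 1 as follows: 4-(2H-tetrazol-5-yl)thiophen-3-yl in place of 2-(3-methyl-1,2,4-oxadiazol-5-yl)phenyl on an aromatic carbon. The entering group contains the same two rings as in compound 3, a thiophene and a tetrazole, joined to each other differently. The two measured steps of the same kind both lowered the number modestly, so a lowering of similar size is expected here, though the altered joining of the rings adds uncertainty. Compound 4 is therefore estimated at 250 nM, with a range from 80 nM to 800 nM. That estimate corresponds to an expected 4.2-fold lower number from compound 1 to compound 4 (0.62 log units; beyond the scatter).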

Compound 4, half-maximal effective concentration: 150 nM
The estimate for compound 4 lay 1.7-fold (0.22 log units) above the measured number; low and high end bracket the measured number.
By their numbers in this assay, from the lowest: compounds 3, 4 and 2 (each within the scatter of the next); then compound 1.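

In this assay, the 4-(2H-tetrazol-5-yl)thiophen-3-yl group in place of the 2-(3-methyl-1,2,4-oxadiazol-5-yl)phenyl group gives a 7.0-fold lower number from compound 1 to compound 4 (0.85 log units; beyond the scatter) and so joins the two earlier tetrazole-bearing groups in lowering the number. How the thiophene and tetrazole are joined makes no readable difference (a 1.1-fold higher number from compound 3 to compound 4 (0.03 log units; within the scatter)), and the thiophene and pyrrole groups cannot be told apart either (a 1.8-fold lower number from compound 2 to compound 4 (0.26 log units; within the scatter)), so at this position the three groups are equivalent within the scatter. Among the compounds shown here, no measurement at hand explains what sets these groups apart from the one in compound 1.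

Both rings differ between compound 1 and compound 4, so the shown compounds cannot separate the effect of the tetrazole from that of the thiophene. As far as these compounds go, a carboxylic acid in the tetrazole's place on the thiophene, or a tetrazole on the phenyl ring, remains open.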